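A few compounds are considered here, and "the series" means these few. Any claim that something is new, unique, unknown or untested is made for them only; others in the source may bear on it.

Compound 1 `CC(C)=CCC[C@@](C)(/C=C/c1ccccc1)/C=C/c1ccc(O)cc1` gives in an ADME assay on HEK293 cells (Homo sapiens) for cytotoxicity, with a stated time of 72 h (on this read-out higher numbers stand for an effect only at larger amounts of compound and lower numbers for an effect already at smaller amounts), a value of > 36600 nM, which is a limit of the assay.
Compound 2 `CC(C)=CCC[C@](C)(/C=C/c1ccc(O)cc1)/C=C/c1cccc(F)c1` gives in this assay a value of > 36600 nM, again a limit.
Compound 3 `C=C[C@@](C)(/C=C/c1ccc(Nc2ccc(F)cc2)cc1)CCC=C(C)C` gives in this assay a value of > 36600 nM, also a limit.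

From compound 1 to compound 2 the change is fluoro in place of hydrogen on an aromatic carbon. Its step, a step that the two limits leave unreadable from compound 1 to compound 2, cannot be read, since both values are limits. The difference between the core of compound 1 and that of compound 3 is not broken down here.

Compound 4 `C=C[C@@](C)(/C=C/c1ccc(Nc2ccc(F)c(F)c2)cc1)CCC=C(C)C` differs from compound 3 by fluoro in place of hydrogen on an aromatic carbon. This is the same kind of change as from compound 1 to compound 2, but the place differs: here it is ortho to a fluoro group (1 heavy atom) and meta to a large group, whereas in compound 2 it is only meta to a large group.

In this assay compound 4 is expected to stay at the limit, an expected step that the limit leaves unreadable from compound 3 to compound 4, because the limit of > 36600 nM in this assay, at which 3 of the 3 values shown sit, holds for every compound measured. The estimate for compound 4 is 50000 nM, spanning 20000 nM to 150000 nM.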

Compound 4, half-maximal effective concentration: > 36600 nM
Compound 4: only a limit was reported (the forecaster's own chance of this, stated with the estimate: 85%); the middle value lies beyond the limit too.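

No step can be read between compound 3 and compound 4, as both values are limits: the limit of > 36600 nM in this assay, at which 4 of the 4 values shown sit.

The compounds shown leave open whether fluoro in place of hydrogen on an aromatic carbon changes the read-out in this assay at all.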